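The compounds below may be only part of what the source reports. "The series", "measured", "known", "first", "only" and "open" are said of these compounds alone.

Three compounds have been measured in a functional assay on CHO cells with adenosine receptor A1 (Homo sapiens) as the target, read by cAMP accumulation and immunoassay, with a stated time of 6 min, tested at 1 uM; a higher number here means a weaker effect of the compound at the concentration tested, a lower number a stronger effect:

Compound 1, `Nc1scc(CN2CCN(c3cccc(Cl)c3Cl)CC2)c1C(=O)c1ccc(Cl)cc1`, gives -57%.
Compound 2, `Nc1scc(CN2CCN(c3c(F)cccc3F)CC2)c1C(=O)c1cccc(C(F)(F)F)c1`, gives 1.3%.
Compound 3, `Nc1scc(CN2CCN(c3ccc(F)cc3F)CC2)c1C(=O)c1ccc(Cl)cc1`, gives -66%.

Compound 3 has the lowest of the three numbers in this assay. Going by the values given here, its nearest neighbour is compound 1, and the step of a number 9 percentage points lower from compound 1 to compound 3 (within the scatter) is within the scatter; compound 2 lies far above it, beyond the scatter, though compound 2 and compound 3 differ in two places, so no single step connects them.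

Compound 4, `Nc1scc(CN2CCN(c3c(F)cccc3F)CC2)c1C(=O)c1ccc(Cl)cc1`, has not yet been measured. It differs from compound 3 by 2,6-difluorophenyl in place of 2,4-difluorophenyl on an amine nitrogen in a ring. Among the compounds with values here, the one measured step that touches this position, the step from compound 1 to compound 3, exchanged a different group and was within the scatter, so it gives no direct guide. Compound 2, which carries the same 2,6-difluorophenyl, gives 1.3%, but its other aryl group differs as well, so its number cannot be read as the effect of this change alone. A moderate step upward from compound 3 is therefore expected, a number 31 percentage points higher from compound 3 to compound 4 (beyond the scatter), with wide uncertainty. Compound 4 is estimated at -35%, in the range -75% to 10%.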

Compound 4, a percentage reported as activity, at one concentration (the size of the read-out at that concentration, not a potency): -65%
Compound 4: the middle estimate sits 30 percentage points above what was measured; the range from low to high includes it.
By their numbers in this assay, from the lowest: compounds 3, 4 and 1 (each within the scatter of the next); then compound 2.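

Moving one fluorine on the aryl group at this position gives, in this assay, a number 1 percentage points higher from compound 3 to compound 4 (within the scatter), so with 4-chlorophenyl on the carbonyl carbon, 2,6-difluorophenyl and 2,4-difluorophenyl cannot be told apart here. The exchange for 2,3-dichlorophenyl gives a number 8 percentage points lower from compound 1 to compound 4 (within the scatter) and likewise separates nothing. The large gap to compound 2 now belongs to the other place: with 2,6-difluorophenyl held constant, 4-chlorophenyl in place of 3-(trifluoromethyl)phenyl gives a number 66.3 percentage points lower from compound 2 to compound 4 (beyond the scatter), though no measured evidence here accounts for it.

Going by these compounds, only compound 2 carries 3-(trifluoromethyl)phenyl, so whether the aryl groups on the amine nitrogen are also indistinguishable alongside that group remains open. Also open, on these data alone, is what a longer chain in place of the aryl group on that nitrogen would give.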